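Swapping Chloro for Acetoxy on a Chain Carbon

The compounds below may be only part of what the source reports. "The series", "measured", "known", "first", "only" and "open" are said of these compounds alone.

Compound 1 `O=C(/C(=C/C1CCCCC1)CCl)c1ccccc1` gives 22000 nM in a functional assay on WiDr cells (Homo sapiens) for inhibition, read by sulforhodamine B assay, with a stated time of 48 h (a lower number here means a stronger inhibitor of growth, a higher number a weaker inhibitor of growth), the highest of the three numbers. Compound 2 `O=C(/C(=C/c1ccccc1)CCl)c1ccccc1` gives 18000 nM and compound 3 `O=C(/C(=C/c1ccc(Cl)cc1Cl)CCl)c1ccccc1` gives 13000 nM, both within the scatter of compound 1. Within the data shown here, the only step between neighbours, a 1.2-fold lower number from compound 1 to compound 2 (0.09 log units; within the scatter), changed a different part of the molecule. Compound 4 `CC(=O)OC/C(=C\C1CCCCC1)C(=O)c1ccccc1` differs from compound 1 by acetoxy in place of chloro on a saturated chain carbon bound to a double-bonded chain carbon. No measured step touches this position, and the one step that exists was within the scatter, so nothing shown points to a change beyond the scatter in this assay. Compound 4 is therefore expected to land near compound 1, at about 30000 nM, with a range of 10000 nM to 90000 nM, a step of a 1.4-fold higher number from compound 1 to compound 4 (0.13 log units; within the scatter).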

Compound 4, concentration for 50% growth inhibition: 21000 nM
Compound 4: the middle estimate sits 1.4-fold (0.15 log units) above what was measured; the range from low to high includes it.
By their numbers in this assay, from the lowest: compounds 3, 2, 4 and 1 (each within the scatter of the next).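

Acetoxy in place of chloro on a saturated chain carbon bound to a double-bonded chain carbon gives a 1.0-fold lower number from compound 1 to compound 4 (0.02 log units; within the scatter) in this assay. Among these compounds, this is the first measured change at this position, and although the entering group is larger than chloro, the number stays within the scatter. On the core of compound 1, then, growth inhibition at this level does not depend on the chloro; no measurement here offers an explanation for this.

As far as these compounds go, whether the same swap holds on the cores of compound 2 and compound 3 remains open. So does the effect of an amine or a hydroxyl on this carbon.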